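The source may report more compounds than this note shows. Statements on the series, on what has been measured and on what is new or still open speak of the compounds shown alone.

Of the compounds shown here, three sharing one core have been read in a functional assay with Oryctolagus cuniculus as the target; on this read-out higher numbers stand for weaker inhibition and lower numbers for stronger inhibition. Compound 3 `COc1ccc(-c2nc(C(=O)N=C(N)N)sc2-c2ccc(OC)cc2)cc1` gives > 100 nM, which is a limit of the assay and not a number. Compound 1 `COc1ccc(-c2nc(/N=C(\N)n3ccnc3)sc2-c2ccc(OC)cc2)cc1` gives > 100 nM, which is likewise only a limit. Compound 2 `COc1ccc(-c2nc(CNC(=O)c3cccnc3)sc2-c2ccc(OC)cc2)cc1` alone gives a number, 25 nM. Compound 3 therefore stands at the limit of > 100 nM in this assay, at which 2 of the 3 values shown sit, and the measured step of an at least 4.0-fold higher number from compound 2 to compound 3 (0.60 log units; beyond the scatter) sets it on the weaker side.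

The unmeasured compound 4 `COc1ccc(-c2nc(C(=O)N3CCOCC3)sc2-c2ccc(OC)cc2)cc1` keeps the carbonyl and changes what it carries: a group of 6 heavy atoms (4 carbon, 1 nitrogen, 1 oxygen; one six-membered non-aromatic ring with 2 hetero atoms) in place of a group of 4 heavy atoms (1 carbon, 3 nitrogen; no ring), on a carbonyl carbon. Going by the values given here, no measured step makes this exact exchange, so the evidence bears on it only indirectly. The steps of an at least 4.0-fold lower number from compound 1 to compound 2 (0.60 log units; beyond the scatter) and an at least 4.0-fold higher number from compound 2 to compound 3 (0.60 log units; beyond the scatter) show that changing the group on the core can shift the read-out by at least a modest amount, and compound 2 is the only case that leaves the limit. The step that the two limits leave unreadable from compound 1 to compound 3 has no readable size. A modest move towards stronger inhibition is possible, but compound 4 is expected to stay near the limit, with no change beyond the scatter. The expected step is a step that the limit leaves unreadable from compound 3 to compound 4, and it can be read only against a limit. For compound 4 the estimate is 120 nM, with an expected range from 30 nM to 500 nM.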

Compound 4, half-maximal inhibitory concentration: < 10 nM
Compound 4 gave a limit, no number; the forecaster's own chance of this, stated with the estimate: 55%; middle value at least 12-fold (1.07 log units) away from the limit.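

Placing morpholin-4-yl on the carbonyl carbon gives an at least 10-fold lower number from compound 3 to compound 4 (1.00 log units; beyond the scatter) in this assay, so keeping the carbonyl does not by itself fix the read-out; what the carbonyl carries can move it well beyond the scatter. Going by these compounds alone, the change also separates compound 4 from both other compounds, with an at least 2.5-fold lower number from compound 2 to compound 4 (0.39 log units; beyond the scatter) and an at least 10-fold lower number from compound 1 to compound 4 (1.00 log units; beyond the scatter), and this places compound 4 on the stronger side of all three earlier compounds, including compound 2, the only one with a number. Compound 4 gives < 10 nM, which is a limit of the assay and not a number, so all three steps show only a smallest size: the limit of < 10 nM in this assay, at which 1 of the 4 values shown sits.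

The compounds shown leave open how far compound 4 lies past its limit, and whether the result needs morpholin-4-yl in particular or extends to other groups on the carbonyl carbon. A piperidine, which has a carbon where morpholin-4-yl has its ring oxygen, or an open-chain dimethylamine on the same carbonyl would begin to show whether the ring oxygen or the ring itself goes with the lower number.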